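Swapping the Outer Aryl Group: Compound 1 to Compound 4

The source may hold more compounds than are shown below. What is called first, only, known or untested is meant among the compounds shown, and "the series" means these compounds.

Compound 1 `Cc1cc(Nc2cc(N3CCN(C)CC3)nc(Nc3cccc(Cl)c3)n2)n[nH]1` is the starting point. Within the data shown here, in a functional assay on HeLa cells (Homo sapiens) for antiproliferative activity, read by CCK-8 assay, with a stated time of 72 h (on this read-out lower numbers stand for stronger inhibition and higher numbers for weaker inhibition), compound 1 gives 425 nM, the lowest number of the three compounds measured so far. Compound 2 `Cc1cc(Nc2cc(N3CCN(C)CC3)nc(Nc3ccc(Cl)cc3)n2)n[nH]1` gives 619 nM, and compound 3 `Cc1cc(Nc2cc(N3CCN(C)CC3)nc(Nc3ccc(S(N)(=O)=O)cc3)n2)n[nH]1` gives 3060 nM.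

Compound 4 `COc1ccc(Nc2nc(Nc3cc(C)[nH]n3)cc(N3CCN(C)CC3)n2)cc1` differs from compound 1 in one place: 4-methoxyphenyl in place of 3-chlorophenyl on a nitrogen on an aromatic ring. Among the measured compounds shown here, two measured steps bear on this change. The step of a 1.5-fold higher number from compound 1 to compound 2 (0.16 log units; within the scatter) shows that 4-chlorophenyl in place of 3-chlorophenyl costs little. The step of a 4.9-fold higher number from compound 2 to compound 3 (0.69 log units; beyond the scatter) shows that sulfamoyl in place of chloro on that ring costs more, and the combined step a 7.2-fold higher number from compound 1 to compound 3 (0.86 log units; beyond the scatter) adds up both. The 4-methoxyphenyl group entering in compound 4 brings one hydrogen-bond acceptor, like the sulfamoyl of compound 3, but it is a smaller change than the sulfamoyl, so a weakening that is modest but beyond the scatter is expected in this assay.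

Compound 4 is therefore estimated at 950 nM, with a range from 400 nM to 2500 nM. This estimate means an expected step of a 2.2-fold higher number from compound 1 to compound 4 (0.35 log units; beyond the scatter).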

Compound 4, half-maximal inhibitory concentration: 867 nM
For compound 4 the middle estimate is 1.1-fold (0.04 log units) above the measured one; measured number inside the range.
By their numbers in this assay, from the lowest: compounds 1, 2 and 4 (each within the scatter of the next, the first and the last beyond it); then compound 3.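

Chloro and methoxy on this aromatic carbon cannot be told apart in this assay (a 1.4-fold higher number from compound 2 to compound 4 (0.15 log units; within the scatter)). Methoxy in place of sulfamoyl on the same carbon gives a clear gain (a 3.5-fold lower number from compound 3 to compound 4 (0.55 log units; beyond the scatter)), so among the three groups tried there, sulfamoyl alone stands apart from both others. The full change from 3-chlorophenyl to 4-methoxyphenyl is a modest loss beyond the scatter (a 2.0-fold higher number from compound 1 to compound 4 (0.31 log units; beyond the scatter)), while compound 2, with 4-chlorophenyl, lies within the scatter of both compound 1 and compound 4, so these small differences give no firm ranking of compound 2 against either.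

On these data alone, it remains open how an amine, a carboxylic acid or a longer alkoxy chain on this carbon would behave in this assay. Nothing available here explains why sulfamoyl stands apart from chloro and methoxy.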